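A few compounds are considered here, and "the series" means these few. Any claim that something is new, unique, unknown or untested is made for them only; others in the source may bear on it.

Measured so far in the same test:
Compound 1, `Nc1ccc(/C=C2\SC(=O)N(Cc3cccc(Cl)c3)C2=O)cc1`: 4700 nM
Compound 2, `C=C(Br)C(=O)Nc1cccc(/C=C2\SC(=O)N(Cc3cccc(Cl)c3)C2=O)c1`: 1100 nM
Compound 3, `Nc1ccc(/C=C2\SC(=O)N(Cc3ccc(F)cc3)C2=O)cc1`: 24000 nM

All three were tested in a functional assay on L1210 cells (Mus musculus) for cytotoxicity, read by cell counting, with a stated time of 2 days; on this read-out higher numbers stand for weaker inhibition and lower numbers for stronger inhibition. In that test compound 1 gives 4700 nM, compound 2 gives 1100 nM, and compound 3 gives 24000 nM. Compound 2 has the lowest number of the three; compound 1 is its nearest neighbour and compound 3 lies furthest from it, both gaps beyond the usual scatter. The difference between the core of compound 1 and the core of compound 2 is not broken down here.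

Between compound 1 and compound 3 a single change is made: 4-fluorophenyl in place of 3-chlorophenyl on a saturated chain carbon bound to an amide-type nitrogen in a ring. This change brought a 5.1-fold higher number from compound 1 to compound 3 (0.71 log units; beyond the scatter), a weakening that is clearly beyond the scatter.

Compound 4, `C=C(Br)C(=O)Nc1cccc(/C=C2\SC(=O)N(Cc3ccc(F)cc3)C2=O)c1`, has not yet been measured in this assay. It arises from compound 2 by the same change: 4-fluorophenyl in place of 3-chlorophenyl on a saturated chain carbon bound to an amide-type nitrogen in a ring. Because the matching change gave a 5.1-fold higher number from compound 1 to compound 3 (0.71 log units; beyond the scatter), a weakening of roughly that size is expected from compound 2 to compound 4, though the two cores differ, so the step is expected to carry over only loosely: a 4.1-fold higher number from compound 2 to compound 4 (0.61 log units; beyond the scatter). On that basis compound 4 is estimated to give 4500 nM in this assay, with the expected range running from 1500 nM to 14000 nM.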

Compound 4, half-maximal inhibitory concentration: 680 nM
For compound 4 the middle estimate is 6.6-fold (0.82 log units) above the measured one; the whole stated range lies above it.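

In this assay, replacing 3-chlorobenzyl with 4-fluorobenzyl gives a 1.6-fold lower number from compound 2 to compound 4 (0.21 log units; within the scatter), so on this core the change does not separate the two compounds in any measurable way. The same change therefore does not behave alike on the two cores, and a step seen on one core could not be relied on to predict the step on the other: the same change on two cores in this assay, a 5.1-fold higher number (0.71 log units; beyond the scatter) from compound 1 to compound 3 and a 1.6-fold lower number (0.21 log units; within the scatter) from compound 2 to compound 4, 8.3-fold (0.92 log units) apart, beyond the scatter of two such steps. For the compounds shown here, this does not show which part of the difference between the cores is responsible, since those cores differ by more than one feature, and with only one pair on each core it gives no rule for any further core.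

The compounds shown leave open how the benzyl position would respond on each core to other groups, such as plain phenyl or a phenyl ring carrying a methoxy group, on a saturated chain carbon bound to an amide-type nitrogen in a ring. They also leave open whether the same mismatch between cores would appear if the bromine-bearing side chain of compound 2 were replaced by a plain acetamide, which would help show whether that side chain or some other part of the core matters here.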